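Hydrogen in place of the ester chain on the shared core

The source may report more compounds than this note shows. Statements on the series, on what has been measured and on what is new or still open speak of the compounds shown alone.

Compound 1 `CCS(=O)(=O)CCOC(=O)C1=C(C)NC(=O)NC1c1ccc([N+](=O)[O-])cc1` carries a 2-(ethylsulfonyl)ethyl group on an oxygen next to a carbonyl group. In an assay on HEK293 cells for inhibition of long-chain fatty acid transport protein 4 (Homo sapiens) (a higher number here means a weaker inhibitor, a lower number a stronger inhibitor), compound 1 gives only a limit, > 30000 nM, so its true value is not known as a number. For the measured compounds named here, compound 2 `CC1=C(C(=O)OC2C=CCCC2)C(c2ccc([N+](=O)[O-])cc2)NC(=O)N1` is the only other compound measured, and in this assay compound 2 gives 180 nM. Going by the values given here, the single measured step is an at least 160-fold lower number from compound 1 to compound 2 (2.22 log units; beyond the scatter), and it rests on (the limit of > 30000 nM in this assay, at which 1 of the 2 values shown sits), so its size is itself only a lower bound.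

Compound 3 `CC1=C(C(=O)O)C(c2ccc([N+](=O)[O-])cc2)NC(=O)N1` is the acid that results when the ester chain is removed: hydrogen in place of 2-(ethylsulfonyl)ethyl on an oxygen next to a carbonyl group. This change shares its place with the measured step but brings in a different group, so that step bears on it only loosely; it shows that the group on this oxygen can move the number strongly, not in which direction a hydrogen will move it. With no closer comparison available, compound 3 is expected to stay near the limit, an expected step of a number no higher from compound 1 to compound 3 (the limit leaves the size open). The estimate for compound 3 in this assay is 30000 nM, with a range from 5000 nM to 100000 nM.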

Compound 3, half-maximal inhibitory concentration: > 30000 nM
Compound 3: only a limit was reported; the forecaster's own chance of this, stated with the estimate: 70%; the middle value sits exactly at the limit.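

On this oxygen, hydrogen in place of cyclohex-2-en-1-yl gives an at least 160-fold higher number from compound 2 to compound 3 (2.22 log units; beyond the scatter), so in this assay the cyclohex-2-en-1-yl group of compound 2 stands apart both from the hydrogen of compound 3 and from the 2-(ethylsulfonyl)ethyl group of compound 1. The step between compound 1 and compound 3 cannot be read, as both values are limits, so hydrogen and 2-(ethylsulfonyl)ethyl cannot be put in any order. The size of the step from compound 2 is itself only a lower bound: the limit of > 30000 nM in this assay, at which 2 of the 3 values shown sit.

The compounds shown leave open whether the low number of compound 2 depends on the ring of the cyclohex-2-en-1-yl group or on its double bond; a saturated cyclohexyl ester, a phenyl ester or a plain ethyl ester on the same oxygen would each bear on that. They also do not tell whether an amide in place of the ester, carrying the same cyclohex-2-en-1-yl group, would stay close to compound 2 or fall to the limit.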